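The source may report more compounds than this note shows. Statements on the series, on what has been measured and on what is new or still open speak of the compounds shown alone.

Series in a functional assay on PC-3 cells (Homo sapiens) for inhibition, read by sulforhodamine B assay; on this read-out lower numbers stand for stronger inhibition of growth and higher numbers for weaker inhibition of growth:
- compound 1 `FC(F)(F)c1ccc(-c2ccc(-c3ccc(-c4nc5ccccc5[nH]4)cc3)cc2)cc1`: 45200 nM
- compound 2 `FC(F)(F)Oc1ccc(-c2ccc(-c3ccc(-c4nc5ccccc5[nH]4)cc3)cc2)cc1`: 100000 nM
- compound 3 `COc1ccc(-c2ccc(-c3ccc(-c4nc5ccccc5[nH]4)cc3)cc2)cc1OC`: not yet measured

Going by the values given here, of the two numbers so far, compound 1 gives the lower, 45200 nM. The change under consideration is 3,4-dimethoxyphenyl in place of 4-(trifluoromethyl)phenyl on an aromatic carbon, with 3,4-dimethoxyphenyl in place of 4-(trifluoromethyl)phenyl on an aromatic carbon.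

Among the compounds with values here, only one measured step bears on this: a 2.2-fold higher number from compound 1 to compound 2 (0.34 log units; beyond the scatter). That step swaps trifluoromethyl for trifluoromethoxy and is modest. It offers a loose guide to size, and with a single step the direction in this assay stays poorly defined. A small move is therefore expected, with a slight lean towards a higher number.

The expected step is a 1.3-fold higher number from compound 1 to compound 3 (0.12 log units; within the scatter). For compound 3 the estimated value is 60000 nM, with an expected range of 20000 nM to 150000 nM.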

Compound 3, concentration for 50% growth inhibition: 47100 nM
Compound 3: middle estimate off by 1.3-fold (0.11 log units), on the high side; measured number inside the range.
By their numbers in this assay, from the lowest: compounds 1 and 3 (each within the scatter of the next); then compound 2.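

The change to 3,4-dimethoxyphenyl in place of 4-(trifluoromethyl)phenyl gives a 1.0-fold higher number from compound 1 to compound 3 (0.02 log units; within the scatter) in this assay and so leaves the read-out unmoved within the scatter. The earlier step showed that a swap of trifluoromethyl for trifluoromethoxy can shift the number beyond the scatter, whereas this one shows that replacing the whole 4-(trifluoromethyl)phenyl group, fluorine for oxygen and no hydrogen-bond acceptors for two, need not shift it at all. Nothing available bears on why these two groups read alike.

The compounds shown leave open whether a single methoxy group on this ring would read like the 3,4-dimethoxyphenyl group. They also leave open whether an amine or a carboxylic acid on this ring would move the number in either direction, since only neutral groups appear here.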